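This account rests on a few compounds, and the source may have more. Where it says the series, first, only, none or still open, it means among the compounds named here.

Measured in a functional assay on HCT-116 cells (Homo sapiens) for antiproliferative activity, read by CCK-8 assay, with a stated time of 72 h, tested at 2 uM; on this read-out higher numbers stand for a stronger effect at the one concentration tested and lower numbers for a weaker effect:
- compound 1 `COC(CCn1cnc2c(NCc3ccc(C(=O)Nc4ccccc4N)cc3)nc(Cl)nc21)OC`: 6.39%
- compound 2 `CCCCn1cnc2c(Nc3cccc(Cl)c3)nc(NCOCc3ccc(/C=C/C(=O)Nc4ccccc4N)cc3)nc21`: 4.76%
- compound 3 `CCCCn1cnc2c(NCc3ccc(C(=O)Nc4ccccc4N)cc3)nc(Cl)nc21`: 4.89%

On these numbers compound 3 stands second highest of three, with compound 2 and compound 1 both within the scatter of it; the whole set sits in one narrow, low band. Compound 4 `Nc1ccccc1NC(=O)c1ccc(CNc2nc(Cl)nc3c2ncn3C2CCCC2)cc1` differs from compound 3 by cyclopentyl in place of butyl on an aromatic nitrogen. Among the compounds with values here, no measured step touches the group on this aromatic nitrogen; the only one-place step, a number 1.5 percentage points lower from compound 1 to compound 3 (within the scatter), concerns a different place and stayed within the scatter. Within the data shown here, with every measured compound reading weakly and no step of any size in the set, compound 4 is expected to move no further than the scatter, a number 0.1 percentage points higher from compound 3 to compound 4 (within the scatter). Compound 4 is therefore estimated at 5% in this assay, ranging from 0% to 15%.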

Compound 4, a percentage reported as inhibition, at one concentration (the size of the read-out at that concentration, not a potency): 75.6%
The estimate for compound 4 lay 70.6 percentage points below the measured number, and the stated range ends below it.
By their numbers in this assay, from the lowest: compounds 2, 3 and 1 (each within the scatter of the next); then compound 4.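

In this assay this aromatic nitrogen proves a sensitive position: replacing butyl by cyclopentyl gives a number 70.7 percentage points higher from compound 3 to compound 4 (beyond the scatter) and replacing 3,3-dimethoxypropyl by cyclopentyl gives a number 69.2 percentage points higher from compound 1 to compound 4 (beyond the scatter) on the same core. Butyl and 3,3-dimethoxypropyl had stayed within the scatter of each other, so among these groups only cyclopentyl opens a large step at this place. Nothing available explains why this change raises the number. Going by these compounds, whether the rise depends on a ring, on its size or on branching stays open, and a cyclobutyl, cyclohexyl or isopropyl group on this nitrogen would help separate these readings. A reading at one concentration also leaves the potency of compound 4 open.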